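Amino to (cyclopropylmethyl)amino on compound 3

The source may hold more compounds than are shown below. What is called first, only, known or untested is meant among the compounds shown, and "the series" means these compounds.

In an in vitro ADME assay on microsomes from liver (Homo sapiens) for metabolic stability (on this read-out higher numbers stand for fast clearance and lower numbers for slow clearance), compound 3 (`Nc1ccc(Cn2c(=O)[nH]c3c(N)nc(C(F)(F)F)cc32)cn1`) gives < 7 mL.min-1.g-1 as a limit of the assay and not a number. Compound 1 (`Nc1nc(C(F)(F)F)cc2c1[nH]c(=O)n2Cc1ccc(C(F)(F)F)nc1`) gives < 7 mL.min-1.g-1 as a limit too. Compound 3 thus stands at the low end of the scale (the limit of < 7 mL.min-1.g-1 in this assay, at which 2 of the 3 values shown sit). Compound 2 (`CN1CCN(c2ccc(Cn3c(=O)[nH]c4c(N)nc(C(F)(F)F)cc43)cn2)CC1`) gives 30 mL.min-1.g-1 as a true number.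

Compound 4 (`Nc1nc(C(F)(F)F)cc2c1[nH]c(=O)n2Cc1ccc(NCC2CC2)nc1`) turns the amino group of compound 3 into (cyclopropylmethyl)amino (cyclopropylmethyl in place of hydrogen on a nitrogen on an aromatic ring). Among the compounds with values here, three measured steps bear on this. With 4-methylpiperazin-1-yl in place of trifluoromethyl there was an at least 4.2-fold higher number from compound 1 to compound 2 (0.63 log units; beyond the scatter) in this assay and with amino in place of 4-methylpiperazin-1-yl there was an at least 4.2-fold lower number from compound 2 to compound 3 (0.63 log units; beyond the scatter) in the same read-out. Amino in place of trifluoromethyl gave a step that the two limits leave unreadable from compound 1 to compound 3 and so adds nothing.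

Compound 4 also grows at that group, and compound 2 with 30 mL.min-1.g-1 is the one measured case of a large group there, so a rise is expected on this single example. The expected change is an at least 2.1-fold higher number from compound 3 to compound 4 (0.33 log units; beyond the scatter) and it may still end in a limit. Compound 4 is estimated at 15 mL.min-1.g-1 with an expected range from 7 mL.min-1.g-1 to 40 mL.min-1.g-1 in intrinsic clearance.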

Compound 4, intrinsic clearance in microsomes in the Homo sapiens assay: 121 mL.min-1.g-1
Compound 4: middle estimate off by 8.1-fold (0.91 log units), on the low side, and the stated range ends below it.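

In the Homo sapiens assay, putting cyclopropylmethyl on the amino nitrogen is enough to lift the compound clear of the low end of the scale, with an at least 17-fold higher number from compound 3 to compound 4 (1.23 log units; beyond the scatter), and the comparison with the trifluoromethyl compound gives an at least 17-fold higher number from compound 1 to compound 4 (1.23 log units; beyond the scatter). In the Homo sapiens assay, the result also passes the one earlier high value at this position, with a 4.0-fold higher number from compound 2 to compound 4 (0.61 log units; beyond the scatter), so the highest number shown here does not belong to 4-methylpiperazin-1-yl, the group that until now marked the top of the range. In a physicochemical assay for lipophilicity, measured as octanol-water partition, at pH 7.4 (on this read-out lower numbers stand for lower lipophilicity and higher numbers for higher lipophilicity), compound 3 gives 1.5 and compound 4 gives 3.2. The rise in clearance may be due in part to higher lipophilicity, although this one pair cannot prove it, and the physicochemical assay moves the same way: the measured distribution coefficient of compound 3, 1.5, and of compound 4, 3.2, a number 1.70 log units higher (beyond the scatter)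

As far as these compounds go, it remains open whether the three-membered ring matters or simply the added carbon, which a plain methyl or an open chain such as isobutyl on the same nitrogen could help to separate. From the compounds shown here alone, it also remains open whether a chain carrying a hydroxyl group or a carboxylic acid there would bring clearance back towards that of compound 3.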